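This account rests on a few compounds, and the source may have more. Where it says the series, first, only, none or still open, it means among the compounds named here.

Two compounds of the shared core have numbers in a functional assay on A-431 cells (Homo sapiens) for cytotoxicity, read by MTT assay, with a stated time of 72 h, tested at 30 uM; a higher number here means more inhibition of growth at the concentration tested, a lower number less inhibition of growth. Compound 1 `Cc1ccnc(/C(N)=N/NC(=S)N2CCOCC2)c1` gives 74.6% in this assay. Compound 2 `N/C(=N\NC(=S)N1CCCC1)c1ccccn1` gives 85.2% in this assay, the highest of the two numbers; its nearest neighbour is compound 1, whose number lies lower by an amount beyond the usual scatter. Among the measured compounds shown here, compound 1 and compound 2 differ in more than one place, so their two numbers show only that the pair sits apart. The next compound, compound 3 `Cc1ccnc(/C(N)=N/NC(=S)N2CCCC2)c1`, is compound 2 with one change: methyl in place of hydrogen on an aromatic carbon. For the measured compounds named here, no single-change step of this kind has been measured in this assay. Compound 1 already carries this methyl, though it differs elsewhere as well, and its number sits below that of compound 2. Compound 3 is therefore expected to give 78% in this assay, within 65% to 90%. The estimated step is a number 7.2 percentage points lower from compound 2 to compound 3 (within the scatter), expected to be a small loss at most, possibly nothing beyond the scatter.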

Compound 3, percent growth inhibition at one concentration: 84.2%
Estimate against measurement, compound 3: 6.2 percentage points below, within the range that was stated.
By their numbers in this assay, from the lowest: compounds 1, 3 and 2 (each within the scatter of the next, the first and the last beyond it).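

In this assay, methyl in place of hydrogen on an aromatic carbon, opposite the ring nitrogen, gives a number 1 percentage points lower from compound 2 to compound 3 (within the scatter) and so leaves no readable mark at this position. With that methyl present, pyrrolidin-1-yl in place of morpholin-4-yl on a thiocarbonyl carbon gives a number 9.6 percentage points higher from compound 1 to compound 3 (within the scatter) as a single change, which the two earlier compounds, differing in more than one place, could not isolate. No evidence on hand bears on the cause of either step.

Open at the aromatic carbon is whether a larger or different group, such as a longer alkyl chain, a methoxy group or a carboxylic acid, stays within the scatter. Open on the thiocarbonyl carbon is an open-chain amine such as dimethylamino, and the methyl step with morpholin-4-yl in place.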